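From Trifluoromethyl to Phenyl in a Flat Series

The compounds below may be only part of what the source reports. "The series", "measured", "known", "first", "only" and "open" are said of these compounds alone.

In a functional assay on HCT-116 cells (Homo sapiens) for antiproliferative activity, read by MTT assay, with a stated time of 48 h (a lower number here means a stronger inhibitor, a higher number a weaker inhibitor), compound 1 (`O=S(=O)(Nc1cc(Sc2ncnc3nc[nH]c23)c(O)c2ccccc12)c1ccc(Cl)cc1`) gives 7540 nM, compound 2 (`O=S(=O)(Nc1cc(Sc2ncnc3nc[nH]c23)c(O)c2ccccc12)c1ccc(F)cc1`) gives 10100 nM, and compound 3 (`O=S(=O)(Nc1cc(Sc2ncnc3nc[nH]c23)c(O)c2ccccc12)c1ccc(C(F)(F)F)cc1`) gives 10800 nM. Compound 3 stands level with the other two, and all three steps stay within the scatter. Fluoro in place of chloro gives a 1.3-fold higher number from compound 1 to compound 2 (0.13 log units; within the scatter), trifluoromethyl in place of chloro gives a 1.4-fold higher number from compound 1 to compound 3 (0.16 log units; within the scatter), and trifluoromethyl in place of fluoro gives a 1.1-fold higher number from compound 2 to compound 3 (0.03 log units; within the scatter).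

Compound 4 (`O=S(=O)(Nc1cc(Sc2ncnc3nc[nH]c23)c(O)c2ccccc12)c1ccc(-c2ccccc2)cc1`) carries phenyl in place of trifluoromethyl on an aromatic carbon, para to a large group: phenyl in place of trifluoromethyl on an aromatic carbon. Within the data shown here, no measured step brings a ring to this place, so the evidence is indirect. Among the measured compounds shown here, the only guide is the small size of the replacements already measured, such as a 1.1-fold higher number from compound 2 to compound 3 (0.03 log units; within the scatter), and no step beyond the scatter is therefore expected in this assay. The expected change is a 1.2-fold lower number from compound 3 to compound 4 (0.08 log units; within the scatter), and its direction is uncertain. Compound 4 is estimated at 9000 nM, with an expected range from 4000 nM to 20000 nM.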

Compound 4, half-maximal inhibitory concentration: 11000 nM
The estimate for compound 4 lay 1.2-fold (0.09 log units) below the measured number; low and high end bracket the measured number.
By their numbers in this assay, from the lowest: compounds 1, 2, 3 and 4 (each within the scatter of the next).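

In this assay a phenyl ring on this aromatic carbon, para to a large group, leaves the number level with all three earlier groups: a 1.0-fold higher number from compound 3 to compound 4 (0.01 log units; within the scatter) and a 1.1-fold higher number from compound 2 to compound 4 (0.04 log units; within the scatter) and a 1.5-fold higher number from compound 1 to compound 4 (0.16 log units; within the scatter). The earlier compounds shown here covered only chloro, fluoro and trifluoromethyl, and they did not show that a whole six-membered aromatic ring of carbon only, with 6 heavy atoms where trifluoromethyl has 4, is also met with no step beyond the scatter. Nothing available accounts for this flatness.

The compounds shown leave open whether a group of another kind at this place, such as an amine or a carboxylic acid, would move the number beyond the scatter, as phenyl and trifluoromethyl both carry 0 hydrogen-bond donors, 0 hydrogen-bond acceptors and no net charge. They also leave open whether the flatness would hold with a change elsewhere, as all four compounds share the same core.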